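Trimming one methoxy group from the aminophenyl chalcone pyrazole

A few compounds are considered here, and "the series" means these few. Any claim that something is new, unique, unknown or untested is made for them only; others in the source may bear on it.

Compounds measured in a functional assay on NCI-H460 cells (Homo sapiens) for cytotoxicity, read by sulforhodamine B assay, with a stated time of 48 h, tested at 1 uM; on this read-out lower numbers stand for a stronger effect and higher numbers for a weaker effect at the one concentration tested:
compound 1 `COc1ccc(-c2cc(/C=C/C(=O)c3ccc(N)cc3)[nH]n2)cc1` gives 92%
compound 2 `COc1cc(-c2cc(/C=C/C(=O)c3ccc(N)cc3)[nH]n2)cc(OC)c1OC` gives 78%
compound 3 `COc1cc(-c2cc(/C=C/C(=O)c3ccc(F)c(F)c3)[nH]n2)cc(OC)c1OC` gives 103%

Compound 2 stands lowest of the three numbers; compound 1 and compound 3 both lie higher, beyond the scatter. The one step shown is a number 25 percentage points higher from compound 2 to compound 3 (beyond the scatter). Compound 4 `COc1ccc(-c2cc(/C=C/C(=O)c3ccc(N)cc3)[nH]n2)cc1OC` differs from compound 2 in one place: hydrogen in place of methoxy on an aromatic carbon. Going by the values given here, no measured step matches this change; compound 1 and compound 2 differ in more than one place, so their two values show only that the fewer-methoxy compound sits higher. Compound 4 is therefore expected to show a small step upward, a number 7 percentage points higher from compound 2 to compound 4 (within the scatter), with no strong case for a change beyond the scatter. Compound 4 is estimated at 85%, within 70% to 100%.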

Compound 4, a percentage reported as activity, at one concentration (the size of the read-out at that concentration, not a potency): 94%
The estimate for compound 4 lay 9 percentage points below the measured number; measured number inside the range.
By their numbers in this assay, from the lowest: compound 2; then compounds 1, 4 and 3 (each within the scatter of the next, the first and the last beyond it).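

Within this assay, hydrogen in place of methoxy on an aromatic carbon ortho to a methoxy group gives a number 16 percentage points higher from compound 2 to compound 4 (beyond the scatter) beyond what the earlier compounds could isolate, so this single position matters on its own. Methoxy in place of hydrogen on an aromatic carbon gives a number 2 percentage points higher from compound 1 to compound 4 (within the scatter) and so leaves no readable change at that other position. No evidence here accounts for either step.

From the compounds shown here alone, whether an ethoxy or a hydroxyl group at this position would hold the number of compound 2 stays open. So does whether the same methoxy loss would give a similar step with the 3,4-difluorophenyl group of compound 3 in place of the 4-aminophenyl group.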